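From chloro to methoxy in a cytotoxicity test

A few compounds are considered here, and "the series" means these few. Any claim that something is new, unique, unknown or untested is made for them only; others in the source may bear on it.

Compound 1 `COc1ccc(-c2nc3cc(C(C)O)ccc3[nH]2)cc1` gives > 100000 nM
Compound 2 `C/C(=N\NC(N)=O)c1ccc2[nH]c(-c3ccc(Cl)cc3)nc2c1` gives > 100000 nM
Compound 3 `COc1ccc(-c2nc3cc(/C(C)=N/NC(N)=O)ccc3[nH]2)cc1` is not yet measured

In an ADME assay on MDBK cells (Bos taurus) for cytotoxicity, read by MTT assay, with a stated time of 96 h (a higher number here means that more compound is tolerated, a lower number that less compound is tolerated), compound 2 gives > 100000 nM as a limit of the assay, not a number. Compound 1 gives > 100000 nM as a limit too. The two compounds thus stand together at the limit of > 100000 nM in this assay, at which 2 of the 2 values shown sit, and cannot be ranked against each other.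

Compound 3 differs from compound 2 in one place, with methoxy in place of chloro on an aromatic carbon, para to a large group (methoxy in place of chloro on an aromatic carbon). The same difference reads 4-chlorophenyl to 4-methoxyphenyl.

Among the measured compounds shown here, no measured pair shows this change alone. The expectation therefore rests on compound 2 with its limit > 100000 nM and no step beyond the scatter is expected in this assay for this change. As an estimate, this means a number no higher from compound 2 to compound 3 (the limit leaves the size open) and nothing larger. Compound 3 is estimated at 100000 nM within an expected range of 50000 nM to 200000 nM and a limit of the assay is expected again.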

Compound 3, half-maximal cytotoxic concentration: 25000 nM
The estimate for compound 3 lay 4.0-fold (0.60 log units) above the measured number, outside the stated range (below it).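

In this assay, placing 4-methoxyphenyl where 4-chlorophenyl stood gives an at least 4.0-fold lower number from compound 2 to compound 3 (0.60 log units; beyond the scatter), so this position can affect how much compound the cells tolerate. With methoxy kept, the larger group on the aromatic carbon of the core in place of the smaller one gives an at least 4.0-fold lower number from compound 1 to compound 3 (0.60 log units; beyond the scatter), and among these three compounds, only the one carrying both the methoxy and the larger group has a value below the limit. Both steps are minimum sizes, since compound 1 and compound 2 each give only a limit of the assay, not a number: the limit of > 100000 nM in this assay, at which 2 of the 3 values shown sit.

From the compounds shown here alone, how far the true sizes of these steps reach remains open. Also open, going by these compounds, is whether another group in the same place, such as an amine or a longer alkoxy chain, would lower the tolerated concentration as methoxy does.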